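A few compounds are considered here, and "the series" means these few. Any claim that something is new, unique, unknown or untested is made for them only; others in the source may bear on it.

In an ADME assay on MT4 cells (Homo sapiens) for cytotoxicity, read by MTT assay, with a stated time of 4 days (on this read-out lower numbers stand for higher toxicity in this test and higher numbers for lower toxicity in this test), three compounds on the shared core have been read so far. Compound 1 `CCCNc1nc(C(C)c2c(F)cccc2F)c(C)c(=O)[nH]1`, which carries propylamino, gives 35000 nM. Compound 2 `Cc1c(C(C)c2c(F)cccc2F)nc(N(C)C)[nH]c1=O`, which carries dimethylamino, gives > 17000 nM, and this is a limit. Compound 3 `Cc1c(C(C)c2c(F)cccc2F)nc(N(C)C(C)C)[nH]c1=O`, which carries isopropyl(methyl)amino, gives > 81000 nM, and this too is a limit. Compound 3 therefore stands without an exact number.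

Compound 4 `CCCN(C)c1nc(C(C)c2c(F)cccc2F)c(C)c(=O)[nH]1` has the same atoms joined differently: propyl in place of isopropyl on a nitrogen on an aromatic ring. Its methyl(propyl)amino thus replaces the isopropyl(methyl)amino of compound 3, with propyl in place of isopropyl on a nitrogen on an aromatic ring.

Among the measured compounds shown here, no measured step isolates this exchange. For the measured compounds named here, the only readable step that bears on it is an at least 2.3-fold higher number from compound 1 to compound 3 (0.36 log units; beyond the scatter). The other two, a step that the limit leaves unreadable from compound 1 to compound 2 and a step that the two limits leave unreadable from compound 2 to compound 3, give no size. Compound 4 shares its propyl chain with compound 1, which gives 35000 nM. For compound 4 this suggests a number that may fall short of the limit of compound 3. The expected change is an at least 1.3-fold lower number from compound 3 to compound 4 (0.13 log units; that floor lies within the scatter), and it is expected to be small and toward a lower number, if it can be read at all. For compound 4 the estimated value is 60000 nM, with an expected range from 25000 nM to 130000 nM.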

Compound 4, half-maximal cytotoxic concentration: > 78000 nM
Compound 4: only a limit was reported; the forecaster's own chance of this, stated with the estimate: 45%; middle value at least 1.3-fold (0.11 log units) from the limit.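

In this assay, methyl in place of hydrogen on a nitrogen on an aromatic ring, with the propyl chain kept, now has a step of its own that shows a direction: an at least 2.2-fold higher number from compound 1 to compound 4 (0.34 log units; beyond the scatter). The reading for compound 4 is a limit and not a number, so this step gives only a floor for the size of the change: the limit of > 78000 nM in this assay, at which 1 of the 4 values shown sits. The steps from compound 2 to compound 4 and from compound 3 to compound 4 cannot be read, so the data do not separate propyl from isopropyl on this nitrogen, and they give no order for compound 2, compound 3 and compound 4.

The compounds shown leave open whether a longer chain such as butyl, or a ring amine such as pyrrolidine, in place of methyl(propyl)amino would give an exact number in this assay rather than another limit. They also leave open whether isopropylamino, with hydrogen in place of the methyl on this nitrogen, would give a lower number than compound 3, as the pair of compound 1 and compound 4 does with the propyl chain.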